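This account rests on a few compounds, and the source may have more. Where it says the series, first, only, none or still open, it means among the compounds named here.

For the measured compounds named here, in a functional assay on L1210 cells (Mus musculus) for antiproliferative activity, read by MTT assay, with a stated time of 72 h (a higher number here means a weaker inhibitor, a lower number a stronger inhibitor), compound 1 `COc1cc(C2=NN(C(C)=O)C(c3ccc([N+](=O)[O-])cc3)O2)cc(OC)c1OC` gives 4200 nM and compound 2 `COc1cccc(C2OC(c3cc(OC)c(OC)c(OC)c3)=NN2C(C)=O)c1` gives 45000 nM, the higher of the two numbers so far. Compound 3 `COc1ccc(OC)c(C2OC(c3cc(OC)c(OC)c(OC)c3)=NN2C(C)=O)c1` has not yet been measured. Its difference from compound 2 is methoxy in place of hydrogen on an aromatic carbon. In words, this is methoxy in place of hydrogen on an aromatic carbon, giving 2,5-dimethoxyphenyl in place of 3-methoxyphenyl.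

Going by the values given here, only one measured step bears on this change: an 11-fold higher number from compound 1 to compound 2 (1.03 log units; beyond the scatter). This large step, beyond the scatter, replaces 4-nitrophenyl with 3-methoxyphenyl on a saturated ring carbon. Among the compounds with values here, it shows that the number in this assay can move strongly with the group at that carbon, but it does not isolate the addition of a methoxy, and no measured pair tests one. No step beyond the scatter is therefore expected, with only a slight, weakly supported lean toward a lower number and a wide margin on both sides.

For compound 3 the expected value is 30000 nM, with an estimated range of 8000 nM to 90000 nM. This estimate means an expected change a 1.5-fold lower number from compound 2 to compound 3 (0.18 log units; within the scatter).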

Compound 3, half-maximal inhibitory concentration: 55000 nM
Beside the measured number, compound 3's estimate is 1.8-fold (0.26 log units) below it, within the range that was stated.
By their numbers in this assay, from the lowest: compound 1; then compounds 2 and 3 (each within the scatter of the next).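

In this assay the added methoxy, ortho to a large group and para to a methoxy group, gives a 1.2-fold higher number from compound 2 to compound 3 (0.09 log units; within the scatter) and so this single-place addition does not separate 3-methoxyphenyl from 2,5-dimethoxyphenyl in this read-out. With 2,5-dimethoxyphenyl in place of 4-nitrophenyl on the saturated ring carbon, the series shows a 13-fold higher number from compound 1 to compound 3 (1.12 log units; beyond the scatter) and this large step stands alongside an 11-fold higher number from compound 1 to compound 2 (1.03 log units; beyond the scatter) as a second case in which a methoxy-bearing phenyl group at that carbon gives a higher number than 4-nitrophenyl, with no compound shown against that pattern. No measured data on hand explain either the flat methoxy step or the gap to compound 1.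

Still open, as far as these compounds go, is whether the lower number of compound 1 belongs to the nitro group itself or to where that group sits on the phenyl ring, as one nitro compound cannot separate the two. Also open, from the compounds shown here alone, is how this assay responds to a group of another kind on this phenyl ring or at the saturated ring carbon, such as an amine or a carboxylic acid.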